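Compound 1 Gains a Hydroxy

The source may report more compounds than this note shows. Statements on the series, on what has been measured and on what is new or still open speak of the compounds shown alone.

Compound 1 `C=C1C(=O)C2=C3[C@@H](CC[C@H]4C(=C)C(=O)O[C@@H]4[C@@H]13)CC[C@]21C(=O)C[C@H]2C(=C)CC[C@H]3C(=C)C(=O)O[C@@H]3[C@H]21`: > 10000 nM
Compound 2 `C=C1C(=O)O[C@@H]2[C@@H]3C4=C(C(=O)[C@H]3CO)[C@]3(CC[C@]4(O)CC[C@@H]12)C(=O)C[C@H]1C(=C)CC[C@H]2C(=C)C(=O)O[C@@H]2[C@H]13`: > 10000 nM
Compound 3 `C=C1C(=O)C2=C3[C@H](CC[C@H]4C(=C)C(=O)O[C@@H]4[C@@H]13)CC[C@@]21C(=O)C2=C3[C@H]1[C@H]1OC(=O)C(=C)[C@@H]1CC[C@@]3(O)CC[C@]21C(=O)C[C@H]2C(=C)CC[C@H]3C(=C)C(=O)O[C@@H]3[C@H]21`: 7500 nM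

These values come from a functional assay on Huh-7 cells (Homo sapiens) for cytotoxicity, read by CellTiter-Glo, with a stated time of 72 h; a higher number here means a weaker inhibitor, a lower number a stronger inhibitor. Compound 1 stands at the limit of > 10000 nM in this assay, at which 2 of the 3 values shown sit, so its value is a limit and not a number. The value of compound 2 is also a limit. Among the compounds with values here, compound 3, at 7500 nM, has the only numerical value.

Compound 4 `C=C1C(=O)C2=C3[C@H]1[C@H]1OC(=O)C(=C)[C@@H]1CC[C@]3(O)CC[C@]21C(=O)C[C@H]2C(=C)CC[C@H]3C(=C)C(=O)O[C@@H]3[C@H]21` differs from compound 1 by one change: hydroxy in place of hydrogen on a saturated ring carbon. Within the data shown here, no measured step shows this change, so no shift beyond the scatter is expected in this assay. The estimated step, a number no higher from compound 1 to compound 4 (the limit leaves the size open), is only an expectation anchored on the limit of compound 1, > 10000 nM. For compound 4 the expected value is 10000 nM, with an estimated range from 5000 nM to 20000 nM.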

Compound 4, half-maximal inhibitory concentration: 2500 nM
The estimate for compound 4 lay 4.0-fold (0.60 log units) above the measured number; measured number below the stated range.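

In this assay, within the data shown here, hydroxy in place of hydrogen on a saturated ring carbon gives the only step that can be read in this set: an at least 4.0-fold lower number from compound 1 to compound 4 (0.60 log units; beyond the scatter). Among these compounds, the earlier compounds offered no pair differing in one place, so this is the first sign that this position on the six-membered ring of carbon only responds to a change. The value of compound 1 is a limit, so the full size of the step stays open: the limit of > 10000 nM in this assay, at which 2 of the 4 values shown sit.

The compounds shown leave open whether a methoxy or an amine on this carbon would give a similar step. They also leave open whether the hydroxy would give the same step with the opposite stereochemistry at this carbon.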